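The compounds below may be only part of what the source reports. "The series", "measured", "known", "first", "only" and "open" are said of these compounds alone.

Compound 1 `O=C(N/N=C/c1ccc(O)cc1)Nc1ccc(Oc2ccnc3[nH]ccc23)cc1` gives 4920 nM
Compound 2 `O=C(N/N=C/c1ccc(O)cc1Br)Nc1ccc(Oc2ccnc3[nH]ccc23)cc1` gives "not active" (no number reported)

For the measured compounds named here, in a functional assay on PC-3 cells (Homo sapiens) for antiproliferative activity, read by MTT assay, with a stated time of 72 h (on this read-out higher numbers stand for weaker inhibition and lower numbers for stronger inhibition), compound 1 gives a real number (4920 nM), and this is the only number available so far. Compound 2 has just the entry "not active" (no number reported) and therefore no place of its own on the numerical scale.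

Compound 3 `CN(C)CCn1cccc1/C=N/NC(=O)Nc1ccc(Oc2ccnc3[nH]ccc23)cc1` has not yet been measured. The structural change is this (1-(2-(dimethylamino)ethyl)-1H-pyrrol-2-yl in place of 2-bromo-4-hydroxyphenyl on a carbon with a double bond to nitrogen): 1-(2-(dimethylamino)ethyl)-1H-pyrrol-2-yl stands in place of 2-bromo-4-hydroxyphenyl on a carbon with a double bond to nitrogen. The rest of the molecule stays the same.

Going by the values given here, no measured step shows what such a swap does, and without a number for its starting point, the size of the step cannot be stated as a difference. The expected direction in this assay is towards stronger inhibition, from no number to a measurable one. Among the compounds with values here, compound 1 (4920 nM) is the only guide to where that number might fall, and a second result without a number remains a real possibility.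

For compound 3 the estimated half-maximal inhibitory concentration is 3000 nM, with an expected range from 500 nM to 18000 nM.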

Compound 3, half-maximal inhibitory concentration: 3930 nM
Beside the measured number, compound 3's estimate is 1.3-fold (0.12 log units) below it; measured number inside the range.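

In this assay, the group on the carbon with a double bond to nitrogen can be a phenyl ring or something quite different and still give a measurable number. Putting 1-(2-(dimethylamino)ethyl)-1H-pyrrol-2-yl in place of 4-hydroxyphenyl produces a 1.3-fold lower number from compound 1 to compound 3 (0.10 log units; within the scatter), so these two compounds cannot be told apart on this read-out, even though the entering group has a five-membered ring and a side chain ending in an amine. The step from compound 2 cannot be read as a size since compound 2 has no number, and no other measurement is available to explain any of these results.

The compounds shown do not separate the contributions of the ring and the side chain: a plain pyrrol-2-yl group with no side chain, or a chain ending in a morpholine, would help to do so. On these data alone, it also remains open whether the "not active" entry for compound 2 is specific to bromine, which a chlorine or a fluorine in its place would begin to test.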